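The source may report more compounds than this note shows. Statements on the series, on what has been measured and on what is new or still open speak of the compounds shown alone.

Compound 1 `Cc1nc(NC(=O)NC2CCCCC2)c(C)c(C(OC(C)(C)C)C(=O)O)c1-c1ccc2c(c1C)CCCO2` gives 11000 nM in an ADME assay on MT4 cells (Homo sapiens) for cytotoxicity, read by MTT assay; on this read-out lower numbers stand for higher toxicity in this test and higher numbers for lower toxicity in this test.
Compound 2 `Cc1ccc(-c2c(C)nc(NC(=O)NC3CCCCC3)c(C)c2C(OC(C)(C)C)C(=O)O)cc1C` gives 7900 nM in this assay.
Compound 3 `Cc1ccc(-c2c(C)nc(C(=O)NCc3ccccc3)c(C)c2C(OC(C)(C)C)C(=O)O)cc1C` gives 54000 nM in this assay.

Among these three, compound 3 stands at the highest number, meaning the lowest toxicity seen so far; the nearest is compound 1 and the furthest is compound 2, and both gaps lie beyond the scatter. Two steps connect the measured compounds. The change a 1.4-fold lower number from compound 1 to compound 2 (0.14 log units; within the scatter) swaps one ring group for another on the shared core and leaves the number essentially unchanged. The change a 6.8-fold higher number from compound 2 to compound 3 (0.83 log units; beyond the scatter) alters the group on the aromatic carbon next to the ring nitrogen and moves the number by a modest but real amount.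

Compound 4 `Cc1ccc(-c2c(C)nc(Nc3nc4ccccc4s3)c(C)c2C(OC(C)(C)C)C(=O)O)cc1C` is not yet measured. It differs from compound 3 at that same position: (1,3-benzothiazol-2-yl)amino in place of benzylcarbamoyl on an aromatic carbon. Going by the values given here, only the step from compound 2 to compound 3 touches this position, and it shows that exchanging the group there can shift the number beyond the scatter. With a third, different group entering, the direction is open, and a partial return toward the numbers of compound 1 and compound 2 seems as plausible as staying near compound 3. Compound 4 is therefore expected to land somewhat lower, an expected step of a 2.5-fold lower number from compound 3 to compound 4 (0.39 log units; beyond the scatter). The estimate for compound 4 in this assay is 22000 nM, ranging from 6000 nM to 70000 nM.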

Compound 4, half-maximal cytotoxic concentration: 6600 nM
For compound 4 the middle estimate is 3.3-fold (0.52 log units) above the measured one, within the range that was stated.
By their numbers in this assay, from the lowest: compounds 4, 2 and 1 (each within the scatter of the next); then compound 3.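

In this assay, the result shows that the high number of compound 3 is not shared by every large group at this position: replacing benzylcarbamoyl with (1,3-benzothiazol-2-yl)amino, both of 10 heavy atoms, gives an 8.2-fold lower number from compound 3 to compound 4 (0.91 log units; beyond the scatter), so heavy-atom count alone does not set the number here. The other comparison at this position, a 1.2-fold lower number from compound 2 to compound 4 (0.08 log units; within the scatter), shows that two quite different groups joined to the aromatic carbon through a nitrogen, one ending in a cyclohexyl ring and the other in a fused aromatic ring system, give numbers that cannot be told apart, while benzylcarbamoyl, joined through its carbonyl carbon, stands apart from both. No measurement at hand explains why these groups differ in toxicity in this test.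

Going by these compounds alone, with only one group joined through a carbonyl carbon, this split rests on very few compounds, and the linking atom cannot be separated from the rest of each group. Benzylamino and cyclohexylcarbamoyl at the same position would keep one end of a group while exchanging the link, and so could test whether the link or the far end tracks the number.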